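This account rests on a few compounds, and the source may have more. Where it says the series, first, only, none or still open, it means among the compounds named here.

Values in a functional assay on C8166 cells (Homo sapiens) for antiproliferative activity, read by MTT assay; a higher number here means that more compound is tolerated, a lower number that less compound is tolerated; each is a limit of the assay, not a number:
- compound 1 `Cc1cc(C)cc(S(=O)(=O)c2c(C(=O)NCC(=O)NN)[nH]c3ccc(Cl)cc23)c1`: > 100 uM
- compound 2 `Cc1cc(C)cc(S(=O)(=O)c2c(C(=O)NN3CCOC3=O)[nH]c3ccc(Cl)cc23)c1`: > 100 uM
- compound 3 `Cc1cc(C)cc(S(=O)(=O)c2c(C(=O)NNC3CCCCC3)[nH]c3ccc(Cl)cc23)c1`: > 100 uM

Compound 3 has no number, only its limit, and the other two compounds stand the same way: the limit of > 100 uM in this assay, at which 3 of the 3 values shown sit.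

The next compound is compound 4 `Cc1cc(C)cc(S(=O)(=O)c2c(C(=O)NNC(=O)NN)[nH]c3ccc(Cl)cc23)c1`. The change is aminocarbamoyl in place of cyclohexyl on an amine nitrogen.

The measured steps that bear on this change all alter the group carried on the same amide-type nitrogen. They are a step that the two limits leave unreadable from compound 1 to compound 3, a step that the two limits leave unreadable from compound 2 to compound 3 and a step that the two limits leave unreadable from compound 1 to compound 2. None of them has a readable size, so none gives a size to carry over. No step beyond the scatter is expected in this assay, in either direction, and compound 4 is expected to be reported as a limit again. The expected step is a step that the limit leaves unreadable from compound 3 to compound 4. For compound 4 the estimate is 120 uM, with an expected range of 50 uM to 300 uM.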

Compound 4, half-maximal toxic concentration: > 100 uM
Compound 4: only a limit was reported; the forecaster's own chance of this, stated with the estimate: 85%; the middle value is on the limit's open side.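

Compound 4 joins compound 1, compound 2 and compound 3 in this assay, and no step among them can be read, because all four stand at one limit: the limit of > 100 uM in this assay, at which 4 of the 4 values shown sit.

The compounds shown leave open the actual tolerated concentration of each compound, and so whether the groups on the amide-type nitrogen differ at all.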